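This account rests on a few compounds, and the source may have more. Where it says the series, first, only, none or still open, it means among the compounds named here.

Of the compounds shown here, two of the same series have been measured in a functional assay on NCI-H460 cells (Homo sapiens) for antiproliferative activity; on this read-out higher numbers stand for weaker inhibition of growth and lower numbers for stronger inhibition of growth. Compound 1, `CCOC(=O)C[C@H]1[C@@H](O[Si](C)(C)C(C)(C)C)[C@H](n2cnc3c(NC(=O)Nc4ccccc4)ncnc32)O[C@@H]1COC(=O)NC`, gives 4.45 nM in this assay. Compound 2, `CNC(=O)NC[C@H]1O[C@@H](n2cnc3c(NC(=O)Nc4ccccc4)ncnc32)[C@H](O[Si](C)(C)C(C)(C)C)[C@@H]1CC(=O)N(C)OC`, gives 7.49 nM in this assay; that is the higher of the two numbers, yet the gap to compound 1 lies within the usual scatter, so the two compounds cannot be told apart on these numbers.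

Compound 3, `CCOC(=O)C[C@H]1[C@@H](O[Si](C)(C)C(C)(C)C)[C@H](n2cnc3c(NC(=O)Nc4ccccc4)ncnc32)O[C@@H]1CNC(=O)NC`, has not been measured. It differs from compound 2 in one place: ethoxy in place of methoxy(methyl)amino on a carbonyl carbon. For the measured compounds named here, no step between measured compounds shows this exact change, so its effect is unknown, and compound 1 already carries the ethoxy on its carbonyl carbon while giving a number close to that of compound 2. The step from compound 2 to compound 3 in this assay is therefore expected to be small, a 1.4-fold lower number from compound 2 to compound 3 (0.13 log units; within the scatter), with no direction beyond the scatter. Compound 3 is estimated at 5.5 nM, between 2.5 nM and 12 nM.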

Compound 3, concentration for 50% growth inhibition: 5.54 nM
Beside the measured number, compound 3's estimate is 1.0-fold (0.00 log units) below it; low and high end bracket the measured number.
By their numbers in this assay, from the lowest: compounds 1, 3 and 2 (each within the scatter of the next).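

Read in this assay, ethoxy in place of methoxy(methyl)amino on a carbonyl carbon gives a 1.4-fold lower number from compound 2 to compound 3 (0.13 log units; within the scatter) and so shows that these two groups cannot be told apart at this position. For the compounds shown here, the same compound also gives a first reading at a second place, where (methylcarbamoyl)amino in place of (methylcarbamoyl)oxy on a saturated chain carbon bound to a saturated ring carbon gives a 1.2-fold higher number from compound 1 to compound 3 (0.10 log units; within the scatter) and again leaves the two compounds indistinguishable. No measurement at hand offers an explanation for either result.

On these data alone, whether a carboxylic acid or a longer chain such as butoxy on the carbonyl carbon would shift the number stays open. So does whether a plain amine on the saturated chain carbon would do so.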